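Chloro in Place of Fluoro on a Second Core

This account rests on a few compounds, and the source may have more. Where it says the series, first, only, none or still open, it means among the compounds named here.

Compound 1 `COc1cc(/C=C2\CN(C)C/C(=C\c3ccc(F)cc3)C2=O)cc(OC)c1` and compound 2 `COc1cc(/C=C2\CN(C)C/C(=C\c3ccc(Cl)cc3)C2=O)cc(OC)c1` share one core, while compound 3 `CN1C/C(=C\c2ccc(F)cc2)C(=O)/C(=C/c2cccc([N+](=O)[O-])c2)C1` and the as yet unmeasured compound 4 `CN1C/C(=C\c2ccc(Cl)cc2)C(=O)/C(=C/c2cccc([N+](=O)[O-])c2)C1` share another; the difference between the two cores is not broken down here. In a functional assay on K562 cells (Homo sapiens) for cytotoxicity, read by MTT assay, with a stated time of 24 h (on this read-out lower numbers stand for stronger inhibition and higher numbers for weaker inhibition), compound 1 gives 11300 nM, compound 2 gives 13300 nM and compound 3 gives 11300 nM. The change from compound 1 to compound 2, (chloro in place of fluoro on an aromatic carbon), made a 1.2-fold higher number from compound 1 to compound 2 (0.07 log units; within the scatter). The change from compound 3 to compound 4 is chloro in place of fluoro on an aromatic carbon, at a place described in the same words, so it is the same change. Because the measured pair shows a 1.2-fold higher number from compound 1 to compound 2 (0.07 log units; within the scatter), the step from compound 3 to compound 4 in this assay is expected to be a 1.2-fold higher number from compound 3 to compound 4 (0.06 log units; within the scatter). Compound 4 is therefore estimated to give 13000 nM, with the expected range running from 6000 nM to 28000 nM.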

Compound 4, half-maximal inhibitory concentration: > 20000 nM
Compound 4 gave a limit, no number (the forecaster's own chance of this, stated with the estimate: 5%); at least 1.5-fold (0.18 log units) between middle value and limit.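

In this assay compound 4 gives > 20000 nM, which is a limit of the assay and not a number. On the second core, chloro in place of fluoro can therefore be read only as a floor, an at least 1.7-fold higher number from compound 3 to compound 4 (0.24 log units; that floor lies within the scatter), and set beside the first core it gives this picture: the same change on two cores in this assay, a 1.2-fold higher number (0.07 log units; within the scatter) from compound 1 to compound 2 and an at least 1.7-fold higher number (0.24 log units; that floor lies within the scatter) from compound 3 to compound 4; the limit leaves it open whether they differ. As far as these compounds go, how far compound 4 lies past its limit is unknown, so these results neither show that the change carries over from one core to the other with the same size nor show that it does not.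

The compounds shown leave open how a bromo group or an amine on the same aromatic carbon would compare with fluoro and chloro. They also leave open whether either group would give a measured number on the second core.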